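Notes on the step from compound 3 to compound 4

The source may report more compounds than this note shows. Statements on the series, on what has been measured and on what is new or still open speak of the compounds shown alone.

Values in an ADME assay on microsomes from liver (Rattus norvegicus) for metabolic stability, read by LC-MS, using NADPH, with a stated time of 10 min, tested at 0.5 uM; on this read-out higher numbers stand for a more stable compound and lower numbers for a less stable compound:
- compound 1 `CC(=O)Nc1cc(-c2ccc(OC[C@@H](N)CC(C)C)c(F)c2)ccn1`: 80%
- compound 2 `COC(=O)Nc1cc(-c2ccc(OC[C@@](C)(N)CC(C)C)c(C)c2)ccn1`: 96%
- compound 3 `COC(=O)Nc1cc(-c2cnc(OC[C@@](C)(N)CC(C)C)c(Cl)c2)ccn1`: 73%

Compound 3, at 73%, and compound 1, at 80%, lie within the usual scatter of each other. Compound 2, at 96%, stands higher than compound 3, and that gap lies beyond the scatter.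

Compound 4 `COC(=O)Nc1cc(-c2ccc(OC[C@@](C)(N)CC(C)C)nc2)ccn1`, not yet measured in this assay, carries hydrogen in place of chloro on an aromatic carbon, ortho to a (2-amino-2,4-dimethylpentyl)oxy group (hydrogen in place of chloro on an aromatic carbon). Among the compounds with values here, no two measured compounds differ in one place only, so the data hold no direct measure of this change. The expectation therefore rests only on the range spanned by the three measured values, and it remains loose. The estimated size is a small upward move within the scatter, a number 5 percentage points higher from compound 3 to compound 4 (within the scatter). The estimate for compound 4 is 78%, with an expected range from 58% to 94%.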

Compound 4, percent of the compound remaining: 96%
Compound 4: the middle estimate sits 18 percentage points below what was measured; the whole stated range lies below it.
By their numbers in this assay, from the lowest: compounds 3 and 1 (each within the scatter of the next); then compounds 2 and 4 (each within the scatter of the next).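

In this assay, within the data shown here, hydrogen in place of chloro on an aromatic carbon, ortho to a (2-amino-2,4-dimethylpentyl)oxy group, gives a number 23 percentage points higher from compound 3 to compound 4 (beyond the scatter) as the first step that isolates a single place. Among these compounds, what sits on this carbon can therefore move the read-out by itself, with hydrogen on the higher side and chloro on the lower; the earlier compounds, which differ in several places at once, could not separate this contribution. No measurement shown accounts for the size or direction of this step.

From the compounds shown here alone, only chloro and hydrogen have been compared at this carbon, so the effect of a methoxy or nitrile group there remains open. This single pair also leaves open whether the same step would appear on a different core.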